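The source may hold more compounds than are shown below. What is called first, only, known or untested is meant among the compounds shown, and "the series" means these compounds.

In an ADME assay on MT4 cells (Homo sapiens) for cytotoxicity, read by MTT assay (on this read-out higher numbers stand for lower toxicity in this test and lower numbers for higher toxicity in this test), compound 2 `O=C1c2ccccc2C(=O)N1CCOC(=S)N(C(=O)c1cc(F)cc(F)c1)c1ccc(Cl)cc1` gives 59000 nM, the higher of the two numbers recorded so far; its nearest neighbour, compound 1 `O=C1c2ccccc2C(=O)N1CCOC(=S)N(C(=O)c1cc(F)ccc1F)c1ccc(Cl)cc1`, gives 54000 nM in this assay, and the step of a 1.1-fold higher number from compound 1 to compound 2 (0.04 log units; within the scatter) lies within the scatter. Compound 3 `O=C1c2ccccc2C(=O)N1CCOC(=S)N(C(=O)c1ccc(Cl)c([N+](=O)[O-])c1)c1ccc(Cl)cc1` is not yet measured. It differs from compound 2 in one place: 4-chloro-3-nitrophenyl in place of 3,5-difluorophenyl on a carbonyl carbon. Among the compounds with values here, the only measured step that bears on this change is the one from compound 1 to compound 2, a swap at the same carbonyl carbon, and it moved the number by no more than the scatter. Nothing measured touches a nitro group or a chlorine on this ring, so the expected step is set near zero, with a widened range to allow for the larger, more polar ring that enters: a 1.3-fold lower number from compound 2 to compound 3 (0.12 log units; within the scatter). Compound 3 is therefore estimated at 45000 nM, with a range from 15000 nM to 120000 nM.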

Compound 3, half-maximal cytotoxic concentration: 48000 nM
The estimate for compound 3 lay 1.1-fold (0.03 log units) below the measured number; the measured number falls inside the stated range.
By their numbers in this assay, from the lowest: compounds 3, 1 and 2 (each within the scatter of the next).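

Set against compound 2, the 4-chloro-3-nitrophenyl ring gives a 1.2-fold lower number from compound 2 to compound 3 (0.09 log units; within the scatter) in this assay and, set against compound 1, it gives a 1.1-fold lower number from compound 1 to compound 3 (0.05 log units; within the scatter) on the same read-out. The earlier pair showed only that the two fluorines could sit differently on the ring, whereas here both fluorines give way to a nitro group and a chlorine, hydrogen-bond acceptors enter, and both steps remain within the scatter. No measurement shown accounts for this result.

On these data alone, all three compounds carry a halogen-bearing phenyl ring on this carbonyl carbon, so it remains open whether an amine or a carboxylic acid on the ring would leave the number equally unmoved. The same holds for a saturated ring or a longer alkyl chain in place of the phenyl ring.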